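Ethyl for Methyl Tested Across Two Related Cores

The source may hold more compounds than are shown below. What is called first, only, known or untested is meant among the compounds shown, and "the series" means these compounds.

In a functional assay on the whole organism with Rattus norvegicus as the target, read by paw edema, with a stated time of 3 h, at a dose of 100 mg/kg by the oral route (on this read-out higher numbers stand for more inhibition at the one dose given (going by the name of the read-out) and lower numbers for less inhibition), compound 1, `Cc1ccc(-c2nc3cc(Cl)ccc3[nH]2)nc1`, gives -5%. Compound 3, `CCc1ccc(-c2nc3cc(Cl)ccc3[nH]2)nc1`, carries one change from it: methyl in place of hydrogen on a saturated chain carbon bound to an aromatic carbon. In this assay compound 3 gives -2%. That change gave a number 3 percentage points higher from compound 1 to compound 3 (within the scatter). Compound 2, `Cc1ccc2[nH]c(-c3cccc(C)n3)nc2c1`, is built on another core; the difference between the two cores is not broken down here. In this assay compound 2 gives 42%, the highest of the three numbers and beyond the scatter from both compound 1 and compound 3. Compound 4, `CCc1cccc(-c2nc3cc(C)ccc3[nH]2)n1`, is made from compound 2 by the same change: methyl in place of hydrogen on a saturated chain carbon bound to an aromatic carbon. Because the earlier step of a number 3 percentage points higher from compound 1 to compound 3 (within the scatter) stayed within the scatter, the new step is expected to be small as well, a number 2 percentage points higher from compound 2 to compound 4 (within the scatter). Compound 4 is therefore estimated at 44% in this assay, with a likely span from 26% to 62%.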

Compound 4, a percentage reported as inhibition, in the whole organism at one dose (the size of the read-out at that dose, not a potency): 10%
The estimate for compound 4 lay 34 percentage points above the measured number, and the stated range ends above it.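

On the core of compound 2, the change from methyl to ethyl gave a number 32 percentage points lower from compound 2 to compound 4 (beyond the scatter) in this assay, so the small step seen on the other core did not carry over. The size of this step therefore depends on the core that carries it, at least for these two pairs: the same change on two cores in this assay, a number 3 percentage points higher (within the scatter) from compound 1 to compound 3 and a number 32 percentage points lower (beyond the scatter) from compound 2 to compound 4, 35 percentage points apart, beyond the scatter of two such steps. This does not show which feature of the two cores is responsible, and one pair per core cannot say how any other core would respond.

From the compounds shown here alone, only methyl and ethyl are compared here, so it remains open how a longer chain such as propyl, or an amine or a carboxylic acid in its place, would read on either core.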